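The compounds below may be only part of what the source reports. "The series", "measured", "known", "first", "only" and "open" are said of these compounds alone.

Measured so far in an assay on isolated protein for inhibition of DNA topoisomerase 1 (Homo sapiens), with a stated time of 30 min, tested at 100 uM; a higher number here means a stronger effect of the compound at the concentration tested, a lower number a weaker effect:
compound 1, `Cc1ccc2c(=O)[nH]c(-c3cccc(OC(F)(F)F)c3)nc2c1`, 77.2%
compound 2, `Cc1ccc2nc(-c3ccccc3C(F)(F)F)[nH]c(=O)c2c1`, 72%

Compound 1 is the reference for the step that follows. Its number in this assay and that of compound 2 lie within the scatter of each other, so the two compounds are not separated by these data, and neither can be placed above the other.

Compound 3, `Cc1cccc(-c2nc3cc(C)ccc3c(=O)[nH]2)c1`, has not yet been measured in this assay. Against compound 1 the change is methyl in place of trifluoromethoxy on an aromatic carbon, on an aromatic carbon of a six-membered aromatic ring of carbon only. Among the compounds with values here, no pair of measured compounds shows this change, so its effect in this assay has no precedent here. Within the data shown here, a step of small to moderate size is expected, more likely downward than upward, since the only two numbers known both sit at the same level and a change of this kind leaves less room above than below.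

Compound 3 is therefore estimated at 65% in this assay, with a range from 40% to 85%. This estimate means a step of a number 12.2 percentage points lower from compound 1 to compound 3 (beyond the scatter), expected but not yet measured.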

Compound 3, a percentage reported as inhibition, at one concentration (the size of the read-out at that concentration, not a potency): 100%
Compound 3: middle estimate off by 35 percentage points, on the low side, and the stated range ends below it.
By their numbers in this assay, from the lowest: compounds 2 and 1 (each within the scatter of the next); then compound 3.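

In this assay, methyl in place of trifluoromethoxy on an aromatic carbon, meta to a large group, gives a number 22.8 percentage points higher from compound 1 to compound 3 (beyond the scatter). Within the data shown here, this is the first single-place step and shows that the read-out responds to the group at this position, and that the trifluoromethoxy, with its 5 heavy atoms and 1 hydrogen-bond acceptor, is not needed for the effect: methyl, with 1 heavy atom and no hydrogen-bond acceptor, gives a larger effect at the concentration tested. No measurement available here bears on why the step goes in this direction.

The compounds shown leave open whether the gain comes from the methyl itself or simply from the loss of the trifluoromethoxy, a question that plain hydrogen, methoxy, chlorine or an ethyl chain on the same carbon would help to settle. An amine or a carboxylic acid there remains an open case too, and since this step rests on one read-out at one concentration, it gives no potency for compound 3 or compound 1.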